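The source may report more compounds than this note shows. Statements on the series, on what has been measured and on what is new or still open speak of the compounds shown alone.

In a functional assay (aorta) with Rattus norvegicus as the target (a lower number here means that less compound is needed, a higher number that more compound is needed for the effect), compound 1 (`CNC(=O)C1=CC(C(F)(F)F)(C(F)(F)F)Oc2ccc([N+](=O)[O-])cc21`) gives 1.48 nM, compound 2 (`CC1(C(F)(F)F)C=C(/C(S)=N\CCC#N)c2cc([N+](=O)[O-])ccc2O1`) gives 0.363 nM and compound 3 (`N#CCC/N=C(/S)C1=CC(C(F)(F)F)(C(F)(F)F)Oc2ccc([N+](=O)[O-])cc21`) gives 0.437 nM. Compound 3 therefore holds the middle of the three numbers, although a 1.2-fold higher number from compound 2 to compound 3 (0.08 log units; within the scatter) separates it only slightly from compound 2. Compound 4 (`N#CCCNC(=O)C1=CC(C(F)(F)F)(C(F)(F)F)Oc2ccc([N+](=O)[O-])cc21`) has not yet been measured. It departs from compound 3 in one place: a group of 7 heavy atoms (4 carbon, 2 nitrogen, 1 oxygen; no ring) in place of a group of 7 heavy atoms (4 carbon, 2 nitrogen, 1 sulfur; no ring), on a double-bonded ring carbon. The group entering is (2-cyanoethyl)carbamoyl.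

The closest evidence is a 3.4-fold lower number from compound 1 to compound 3 (0.53 log units; beyond the scatter). That step also runs between a carbonyl compound and the sulfur-containing compound 3, but it changes the chain too, so it only roughly bounds the present change. The trifluoromethyl step sits elsewhere on the core and offers little guidance. Compound 4 shares its carbonyl with compound 1 and its chain length with compound 3, so a number between those two, or close to them, is expected. The expected change is a 2.3-fold higher number from compound 3 to compound 4 (0.36 log units; beyond the scatter). For compound 4 the estimated value is 1 nM, with an expected range from 0.35 nM to 3.5 nM.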

Compound 4, half-maximal effective concentration: 0.49 nM
Beside the measured number, compound 4's estimate is 2.0-fold (0.31 log units) above it; the measured number falls inside the stated range.
By their numbers in this assay, from the lowest: compounds 2, 3 and 4 (each within the scatter of the next); then compound 1.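

With the chain held fixed, replacing the sulfur-containing group with (2-cyanoethyl)carbamoyl on the double-bonded ring carbon gives a 1.1-fold higher number from compound 3 to compound 4 (0.05 log units; within the scatter) in this assay, so this exchange leaves the number within the scatter, which the earlier step from the smaller amide could not show. The chain change can now be read alone: cyanomethyl in place of hydrogen on the saturated chain carbon bound to an amide-type nitrogen gives a 3.0-fold lower number from compound 1 to compound 4 (0.48 log units; beyond the scatter) in this assay and separates the two amides beyond the scatter. No measurement offered here explains either result.

The compounds shown leave open whether the nitrile is needed at the chain end, or whether a plain propyl chain or a carboxylic acid there would serve as well. They also leave open whether the same exchange at this position would stay within the scatter with methyl in place of one trifluoromethyl.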